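Benzyl for tert-butyl on the carbamate oxygen

The source may hold more compounds than are shown below. What is called first, only, known or untested is meant among the compounds shown, and "the series" means these compounds.

Measured compounds:
compound 1, `O=C(OCc1ccccc1)N1CCN(C(=S)SCc2cn(Cc3ccc(Cl)cc3)nn2)CC1`, > 128000 nM in a functional assay on PC-3 cells (Homo sapiens) for inhibition, read by MTT assay, with a stated time of 72 h; on this read-out higher numbers stand for weaker inhibition and lower numbers for stronger inhibition
compound 2, `Cc1ccc(Cn2cc(CSC(=S)N3CCN(C(=O)OC(C)(C)C)CC3)nn2)cc1`, 17300 nM in this assay

Within the data shown here, compound 2 is the only compound with a number in this assay. The value of compound 1 is a limit of the assay, not a number (the limit of > 128000 nM in this assay, at which 1 of the 2 values shown sits).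

Compound 3 is `Cc1ccc(Cn2cc(CSC(=S)N3CCN(C(=O)OCc4ccccc4)CC3)nn2)cc1`. It differs from compound 2 by benzyl in place of tert-butyl on an oxygen next to a carbonyl group. Among the measured compounds shown here, no step of this kind has been measured. Compound 1, which carries the benzyloxycarbonyl, sits at a limit; compound 3 carries the same group with the 4-methylbenzyl of compound 2. The expected step is a 2.9-fold higher number from compound 2 to compound 3 (0.46 log units; beyond the scatter), towards weaker inhibition, beyond the scatter. Compound 3 is estimated at 50000 nM, between 15000 nM and 160000 nM.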

Compound 3, half-maximal inhibitory concentration: > 128000 nM
Compound 3 was reported as a limit; the forecaster's own chance of this, stated with the estimate: 35%; middle value at least 2.5-fold (0.40 log units) from the limit.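

In this assay, benzyl in place of tert-butyl on an oxygen next to a carbonyl group gives an at least 7.3-fold higher number from compound 2 to compound 3 (0.86 log units; beyond the scatter), so this change on the 4-methylbenzyl compound is a clear loss rather than something hidden by the chloro group of compound 1. Compound 3 is at a limit of the assay, as is compound 1, and the step between them cannot be read: the limit of > 128000 nM in this assay, at which 2 of the 3 values shown sit.

Going by these compounds, the full size of the benzyl step stays open. So does whether ethyl or an amine-bearing chain in place of tert-butyl would keep a readable number in this assay.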